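A few compounds are considered here, and "the series" means these few. Any claim that something is new, unique, unknown or untested is made for them only; others in the source may bear on it.

Measured so far:
- compound 1 `O=C(NCc1ccc(CNS(=O)(=O)c2cccc(Cl)c2)cc1)c1ccc(CNc2ncccn2)cc1`: 1 nM
- compound 2 `O=C(NCc1ccc(CNS(=O)(=O)c2ccc(-c3ccc(F)cc3)cc2)cc1)c1ccc(CNc2ncccn2)cc1`: 1000 nM

In an assay on MDA-MB-231 cells for binding affinity to C-X-C chemokine receptor type 4 (Homo sapiens), read by microscopy, with stated times of 10 min and 30 min (on this read-out lower numbers stand for an effect already at smaller amounts and higher numbers for an effect only at larger amounts of compound), compound 1 gives the lowest of the two numbers; compound 2 gives a much higher number, well beyond the usual scatter, so on these two points compound 1 is the stronger binder. Among the compounds with values here, no direct single-point step between measured compounds is available, and the change to compound 2 is of a different kind, so it carries little weight here.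

Compound 3 `O=C(NCc1ccc(CNS(=O)(=O)c2ccccc2F)cc1)c1ccc(CNc2ncccn2)cc1` differs from compound 1 only at one place: 2-fluorophenyl in place of 3-chlorophenyl on a sulfonyl sulfur. Within the data shown here, the data give no measured step for an exchange of this kind. Some loss of affinity relative to compound 1 is expected, but a modest one; the step of an 8.0-fold higher number from compound 1 to compound 3 (0.90 log units; beyond the scatter) is estimated to lie outside the scatter yet far short of the gap to compound 2. Compound 3 is therefore expected to give about 8 nM in this assay, within a range of 1.5 nM to 50 nM.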

Compound 3, effective concentration (reported as EC, without a stated level of effect): 1000 nM
Estimate against measurement, compound 3: 130-fold (2.10 log units) below, outside the stated range (above it).
By their numbers in this assay, from the lowest: compound 1; then compounds 2 and 3 (each within the scatter of the next).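

In this assay, the group on the sulfonyl sulfur proves to be a sensitive position: 2-fluorophenyl in place of 3-chlorophenyl gives a 1000-fold higher number from compound 1 to compound 3 (3.00 log units; beyond the scatter), a large step. The exchange leaves the heavy-atom count, the hydrogen-bond donor and acceptor counts and the net charge unchanged, so these counts do not separate the two groups. No available evidence explains the size of this step.

This exchange changes both the halogen and where it sits on the ring, so the two changes cannot be separated here; 3-fluorophenyl and 2-chlorophenyl on the same sulfonyl sulfur would divide them. Also open, going by these compounds, is how plain phenyl, or a phenyl ring carrying an amine or a carboxylic acid, would read at this position.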